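A Dienone Series: Swapping Chloro for Dimethylamino

The source may hold more compounds than are shown below. What is called first, only, known or untested is meant among the compounds shown, and "the series" means these compounds.

Of the compounds shown here, two built on a shared core have been measured so far. Compound 1 `O=C1C=CCC/C1=C\C=C\c1ccc(Cl)cc1` carries a chloro group on its aromatic ring, and in a functional assay on Bel7402/5-FU cells (Homo sapiens) for cytotoxicity, read by MTT assay, with a stated time of 72 h (on this read-out higher numbers stand for weaker inhibition and lower numbers for stronger inhibition), compound 1 gives 3200 nM. Its companion, compound 2 `COc1ccccc1/C=C/C=C1\CCC=CC1=O`, gives in this assay 2500 nM. Compound 1 has the larger of the two numbers on paper, yet its gap to compound 2 lies within the usual scatter of such measurements, so the two compounds cannot be told apart on this evidence. Within the data shown here, no pair of measured compounds differs in a single place, so no measured step is available to guide the next move.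

The third compound, compound 3 `CN(C)c1ccc(/C=C/C=C2\CCC=CC2=O)cc1`, differs from compound 1 in one respect: dimethylamino in place of chloro on an aromatic carbon. With no measured step of this kind in hand, the size of the change can only be guessed. Compound 3 is expected to show a modest move toward stronger inhibition, a 1.6-fold lower number from compound 1 to compound 3 (0.20 log units; within the scatter), though a result within the scatter of compound 1 would not surprise. Compound 3 is therefore estimated at 2000 nM, with a plausible range from 700 nM to 6000 nM.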

Compound 3, half-maximal inhibitory concentration: 1000 nM
Estimate against measurement, compound 3: 2.0-fold (0.30 log units) above; the measured number falls inside the stated range.
By their numbers in this assay, from the lowest: compound 3; then compounds 2 and 1 (each within the scatter of the next).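

In this assay, among these compounds, the replacement of chloro by dimethylamino on an aromatic carbon, para to a large group, gives a 3.2-fold lower number from compound 1 to compound 3 (0.51 log units; beyond the scatter) and so provides the first measured step, one that lies beyond the scatter. Among the compounds shown here, it shows that the number in this assay responds to the group at this place on the aromatic ring, a point the earlier compounds could not show, since no two of them differed in one place and their values lay within the scatter of each other. Nothing available accounts for this step, so its cause stays unexplained.

The compounds shown leave open whether the step belongs to the nitrogen of dimethylamino or simply to its greater number of heavy atoms, a question that a plain amino group, a diethylamino group or an isopropyl group at the same place would help to settle. They also leave open whether the same replacement would give a step of similar size at another place on the aromatic ring.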